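A few compounds are considered here, and "the series" means these few. Any claim that something is new, unique, unknown or untested is made for them only; others in the source may bear on it.

Measured in a functional assay on HT-29 cells (Homo sapiens) for inhibition; a higher number here means a weaker inhibitor of growth, a lower number a stronger inhibitor of growth:
Compound 1 `COc1ccc(-n2cnnc2-c2cc(OC)c(OC)c(OC)c2)cc1` gives 2140 nM
Compound 2 `COc1cc(-c2nncn2-c2ccc(N(C)C)cc2)cc(OC)c1OC` gives 30.9 nM
Compound 3 `COc1ccc(-n2cnnc2-c2cc(OC)c(OC)c(OC)c2)cc1O` gives 2880 nM

Compound 3, at 2880 nM, lies within the scatter of compound 1 and well above compound 2, the strongest inhibitor of the three. Compound 4 `COc1ccc(-n2cnnc2-c2cc(OC)c(OC)c(OC)c2)cc1F` differs from compound 3 in one place: fluoro in place of hydroxy on an aromatic carbon. In words, this is fluoro in place of hydroxy on an aromatic carbon.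

Two measured steps can be weighed. The first is a 1.3-fold higher number from compound 1 to compound 3 (0.13 log units; within the scatter), for hydroxy in place of hydrogen on this same carbon. It shows no response to that change. The second is a 69-fold lower number from compound 1 to compound 2 (1.84 log units; beyond the scatter), which is large, but it concerns dimethylamino in place of methoxy on a different carbon, and compound 4 keeps that methoxy. It therefore bears little on this change. Among the measured compounds shown here, no fluoro compound has been measured, so in this assay no step beyond the scatter is expected, and neither direction is favoured.

The expected step is a 1.6-fold lower number from compound 3 to compound 4 (0.20 log units; within the scatter), an estimate that stays within the scatter. Compound 4 is estimated at 1800 nM, with an expected range from 500 nM to 6000 nM as its bounds.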

Compound 4, concentration for 50% growth inhibition: 3160 nM
Compound 4: middle estimate off by 1.8-fold (0.24 log units), on the low side; the measured number falls inside the stated range.
By their numbers in this assay, from the lowest: compound 2; then compounds 1, 3 and 4 (each within the scatter of the next).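

In this assay, placing fluoro on this aromatic carbon, ortho to a methoxy group, gives no step beyond the scatter against hydrogen (a 1.5-fold higher number from compound 1 to compound 4 (0.17 log units; within the scatter)) or against hydroxy (a 1.1-fold higher number from compound 3 to compound 4 (0.04 log units; within the scatter)). The earlier compounds shown here showed only that hydroxy could stand in for hydrogen here; this result adds a second replacement and shows that the hydrogen-bond donor and acceptor counted on hydroxy, both absent from fluoro, are not needed to hold the number within the scatter. Nothing available gives a cause for this flat response.

From the compounds shown here alone, whether an amine, a carboxylic acid or a longer chain on this carbon would also stay within the scatter remains open. Going by these compounds, it is also open whether fluoro or hydroxy here would behave the same way alongside the dimethylamino group of compound 2.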